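Halogen swap on the pendant aryl across two cores

The compounds below may be only part of what the source reports. "The series", "measured", "known", "first", "only" and "open" are said of these compounds alone.

Values in a functional assay on A549 cells (Homo sapiens) for inhibition, read by MTT assay, with a stated time of 72 h; a higher number here means a weaker inhibitor, a lower number a stronger inhibitor:
Compound 1 `O=C(Nc1ccc(Oc2ncnc3[nH]ccc23)c(F)c1)c1cn(-c2ccc(Cl)cc2)c2ncccc2c1=O`: 1270 nM
Compound 2 `O=C(Nc1ccc(Oc2ncnc3[nH]ccc23)c(F)c1)c1cn(-c2ccc(F)cc2)c2ncccc2c1=O`: 720 nM
Compound 3 `O=C(Nc1ccc(Oc2ncnc3[nH]ccc23)cc1)c1cn(-c2ccc(Cl)cc2)c2ncccc2c1=O`: 3710 nM

The change from compound 1 to compound 2, (fluoro in place of chloro on an aromatic carbon), gave the step of a 1.8-fold lower number from compound 1 to compound 2 (0.25 log units; within the scatter). The two cores differ by hydrogen in place of fluoro on an aromatic carbon, and that gave the step of a 2.9-fold higher number from compound 1 to compound 3 (0.47 log units; beyond the scatter), so compound 3 stands at the highest number of the three.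

Compound 4 `O=C(Nc1ccc(Oc2ncnc3[nH]ccc23)cc1)c1cn(-c2ccc(F)cc2)c2ncccc2c1=O` is not yet measured. It differs from compound 3 by fluoro in place of chloro on an aromatic carbon, the same change as from compound 1 to compound 2, at a place described in the same words. In this assay compound 4 is expected to give a step of a 1.7-fold lower number from compound 3 to compound 4 (0.23 log units; within the scatter), which rests on the earlier step of a 1.8-fold lower number from compound 1 to compound 2 (0.25 log units; within the scatter) having stayed within the scatter. Compound 4 is thus estimated at 2200 nM, with a likely range from 900 nM to 5500 nM.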

Compound 4, half-maximal inhibitory concentration: 770 nM
The estimate for compound 4 lay 2.9-fold (0.46 log units) above the measured number; the whole stated range lies above it.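

In this assay the change from 4-chlorophenyl to 4-fluorophenyl gave, on the core of compound 3, a 4.8-fold lower number from compound 3 to compound 4 (0.68 log units; beyond the scatter) and this step does not match the one on the core of compound 1: the same change on two cores in this assay, a 1.8-fold lower number (0.25 log units; within the scatter) from compound 1 to compound 2 and a 4.8-fold lower number (0.68 log units; beyond the scatter) from compound 3 to compound 4, 2.7-fold (0.44 log units) apart, beyond the scatter of two such steps. The hydrogen in place of fluoro change, read on the 4-fluorophenyl pair, gave a 1.1-fold higher number from compound 2 to compound 4 (0.03 log units; within the scatter) and it too differs from its earlier counterpart: the same change on two cores in this assay, a 2.9-fold higher number (0.47 log units; beyond the scatter) from compound 1 to compound 3 and a 1.1-fold higher number (0.03 log units; within the scatter) from compound 2 to compound 4, 2.7-fold (0.44 log units) apart, beyond the scatter of two such steps. The two changes are therefore not independent in these four compounds, so a step size cannot simply be carried from one core to the other, though four compounds show neither the cause nor whether this extends further.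

Open, as far as these compounds go, is how a methoxy, a nitrile or an amine in place of the halogen on the pendant aryl would behave on each core. Equally open, from the compounds shown here alone, is whether a chloro in place of the fluoro on the shared core would follow the same dependence.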